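Aryl substituent: trifluoromethyl exchanged for tert-butyl

The source may hold more compounds than are shown below. What is called first, only, known or untested is meant among the compounds shown, and "the series" means these compounds.

Compound 1 `Cn1ncc2c(NC(=O)NCc3cc(C(C)(C)C)nn3-c3ccc(F)cc3)cccc21` gives 4.5 nM in an assay on CHO-K1 cells for antagonist activity at transient receptor potential cation channel subfamily V member 1 (Homo sapiens), read by FLIPR and calcium flux, with a stated time of 6 min; on this read-out higher numbers stand for weaker inhibition and lower numbers for stronger inhibition. For the measured compounds named here, compound 2 `Cn1ncc2c(NC(=O)NCc3cc(C(C)(C)C)nn3-c3ccc(C(F)(F)F)cc3)cccc21` gives 12.4 nM in this assay, the higher of the two numbers measured so far; its nearest neighbour is compound 1, and the step of a 2.8-fold higher number from compound 1 to compound 2 (0.44 log units; beyond the scatter) lies beyond the scatter. Compound 3 `Cn1ncc2c(NC(=O)NCc3cc(C(C)(C)C)nn3-c3ccc(C(C)(C)C)cc3)cccc21` carries the change (tert-butyl in place of trifluoromethyl on an aromatic carbon), sited on an aromatic carbon of a six-membered aromatic ring of carbon only, para to a large group. Going by the values given here, the only measured step that touches this position is a 2.8-fold higher number from compound 1 to compound 2 (0.44 log units; beyond the scatter), a modest rise in the number. Among the compounds with values here, no measured pair exchanges trifluoromethyl for tert-butyl, so the expected step of a 1.3-fold higher number from compound 2 to compound 3 (0.11 log units; within the scatter) rests on that single precedent and is taken to be small, most likely a slight further rise or nothing beyond the scatter. Compound 3 is therefore estimated at 16 nM in this assay, with a range from 6 nM to 45 nM.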

Compound 3, inhibition constant: 46.3 nM
Compound 3: the middle estimate sits 2.9-fold (0.46 log units) below what was measured; measured number above the stated range.
By their numbers in this assay, from the lowest: compound 1; then compound 2; then compound 3.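

In this assay this position proves sensitive to the exchange, which gives a 3.7-fold higher number from compound 2 to compound 3 (0.57 log units; beyond the scatter), even though trifluoromethyl and tert-butyl match in heavy-atom count and neither carries a net charge. With the fluoro compound included, the span at this position reaches a 10-fold higher number from compound 1 to compound 3 (1.01 log units; beyond the scatter), and the numbers rise in the order fluoro, trifluoromethyl, tert-butyl, with none of the three compounds going against that order. Nothing available here bears on the reason for these rises.

Still open, going by these compounds, is whether hydrogen, chloro, methoxy or an amine on this aromatic carbon would extend that order or break it, and whether any of them would give a lower number than compound 1 does. Also open, on these data alone, is whether the same order would hold with a different group in place of the shared core.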